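Taking the hydroxy off compound 2

This account rests on a few compounds, and the source may have more. Where it says the series, first, only, none or still open, it means among the compounds named here.

Values so far in a toxicity assay on cells (Erythrocyte, Homo sapiens) for cytotoxicity, read by hemolysis, with a stated time of 1 h (on this read-out higher numbers stand for weaker inhibition and lower numbers for stronger inhibition), stand as follows
compound 1 `CC(C)=CCC/C(C)=C/CN(c1ccc(O)cc1)S(C)(=O)=O` gives < 0.419 ug/mL as a limit
compound 2 `CC(C)=CCC/C(C)=C/CNc1ccc(O)cc1` gives < 0.419 ug/mL as a limit

Compound 2 is known only through its limit of < 0.419 ug/mL and has no number. The shared reading of the pair is the limit of < 0.419 ug/mL in this assay, at which 2 of the 2 values shown sit, and nothing more. Compound 3 `CC(C)=CCC/C(C)=C/CNc1ccccc1` has hydrogen in place of hydroxy on an aromatic carbon, para to a large group, counted as hydrogen in place of hydroxy on an aromatic carbon in full. Among the measured compounds shown here, the only measured step is a step that the two limits leave unreadable from compound 1 to compound 2 and it concerns a nitrogen, so it offers no size to carry over. The estimated step that the limit leaves unreadable from compound 2 to compound 3 is therefore expected to show no direction beyond the scatter. Compound 3 is estimated at 0.4 ug/mL with an expected range of 0.15 ug/mL to 3 ug/mL in this assay and may again read only as a limit.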

Compound 3, half-maximal inhibitory concentration: < 0.419 ug/mL
Compound 3: no number, only a limit (the forecaster's own chance of this, stated with the estimate: 60%); the middle value is on the limit's open side.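

In this assay, compound 2 and compound 3 both read only as limits, and no step between them can be read: the limit of < 0.419 ug/mL in this assay, at which 3 of the 3 values shown sit.

The compounds shown leave open whether removing the hydroxy or the methylsulfonyl changes the reading in this assay at all, as none of them has a number.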